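Swapping a Ring Substituent on an Antiproliferative Quinoline Acid

The source may hold more compounds than are shown below. What is called first, only, known or untested is meant among the compounds shown, and "the series" means these compounds.

Of the compounds shown here, three sharing one core have been tested in a functional assay on Hep 3B2 cells (Homo sapiens) for antiproliferative activity, read by MTT assay, with a stated time of 24 h, tested at 33.33 ug/mL; a lower number here means a weaker effect, a higher number a stronger effect of the compound at the concentration tested. Compound 1 `Cc1ccc2nc(C(=O)Nc3c(F)cc(-c4cccc(F)c4)cc3F)c(C)c(C(=O)O)c2c1` gives 41.3%. Compound 2 `Cc1c(C(=O)Nc2c(F)cc(-c3cccc(F)c3)cc2F)nc2ccc(F)cc2c1C(=O)O` gives 34.3%, and compound 3 `CCOc1ccc2nc(C(=O)Nc3c(F)cc(-c4cccc(F)c4)cc3F)c(C)c(C(=O)O)c2c1` gives 38.7%. Compound 3 stands amid the other two on these numbers: a number 2.6 percentage points lower from compound 1 to compound 3 (within the scatter), and a number 4.4 percentage points higher from compound 2 to compound 3 (within the scatter), so its value cannot be separated from either neighbour. The third pairing is no different: a number 7 percentage points lower from compound 1 to compound 2 (within the scatter).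

Compound 4 `Cc1c(C(=O)Nc2c(F)cc(-c3cccc(F)c3)cc2F)nc2ccc(C(F)(F)F)cc2c1C(=O)O` has not yet been measured. It differs from compound 3 in one place: trifluoromethyl in place of ethoxy on an aromatic carbon.

The three measured steps all concern the same aromatic carbon, exchanging methyl, fluoro and ethoxy there, and each stayed within the scatter. Nothing among them points to a direction for a trifluoromethyl at that position, so no step beyond the scatter is expected in this assay. Compound 4 is therefore estimated to give 37%, with a range from 25% to 49%, which is expected to mean a number 1.7 percentage points lower from compound 3 to compound 4 (within the scatter).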

Compound 4, a percentage reported as inhibition, at one concentration (the size of the read-out at that concentration, not a potency): 43.3%
Estimate against measurement, compound 4: 6.3 percentage points below; low and high end bracket the measured number.
By their numbers in this assay, from the lowest: compounds 2, 3, 1 and 4 (each within the scatter of the next).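

At this aromatic carbon, trifluoromethyl joins methyl, fluoro and ethoxy, and in this assay each of its steps stays within the scatter: a number 4.6 percentage points higher from compound 3 to compound 4 (within the scatter), a number 9 percentage points higher from compound 2 to compound 4 (within the scatter), and a number 2 percentage points higher from compound 1 to compound 4 (within the scatter). Even the exchange of ethoxy, which has one hydrogen-bond acceptor, for trifluoromethyl, which has none, leaves the two values inseparable, so these four groups cannot be told apart by this read-out.

On these data alone, it remains open whether a group of another kind at this carbon, such as an amine, a hydroxyl or a longer chain, would give a step beyond the scatter. All four values also come from a single concentration, so they leave open how the compounds would compare in potency. No measurement is available that bears on what lies behind these values.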